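The source may hold more compounds than are shown below. What is called first, only, known or untested is meant among the compounds shown, and "the series" means these compounds.

Measured compounds, inhibition in a functional assay on MV4-11 cells (Homo sapiens) for antiproliferative activity, with a stated time of 6 days, tested at 1.56 uM; a lower number here means a weaker effect, a higher number a stronger effect of the compound at the concentration tested:
compound 1 `CNC(=O)N1CCCc2ccc(NC(=O)c3ccc(-c4cc[nH]n4)cc3)cc21`, 92.5%
compound 2 `CNC(=O)N1CCCc2ccc(NC(=O)c3cccc(-c4ccn(C)n4)c3)cc21`, 70.5%
compound 3 `CNC(=O)N1CCCc2ccc(NC(=O)c3ccc(-c4cnn(C)c4)cc3)cc21`, 77.4%

Compound 2 gives the lowest of the three numbers in this assay; its gap to compound 3 lies within the scatter, while compound 1 stands clearly higher. The step to the unmeasured compound 4 `CNC(=O)N1CCCc2ccc(NC(=O)c3cccc(-c4cn[nH]c4)c3)cc21` is 1H-pyrazol-4-yl in place of 1-methyl-1H-pyrazol-3-yl on an aromatic carbon. Of the measured steps only a number 15.1 percentage points lower from compound 1 to compound 3 (beyond the scatter) bears on it, and only in part: it pairs a methylated pyrazole against an unmethylated one, though at a different ring position and at a different place on the benzene, and the unmethylated partner there was the higher of the pair. Read in that direction, a modest gain is expected for compound 4, a number 9.5 percentage points higher from compound 2 to compound 4 (within the scatter), with compound 4 expected at 80% in this assay, range 64% to 93%.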

Compound 4, a percentage reported as inhibition, at one concentration (the size of the read-out at that concentration, not a potency): 27.9%
Estimate against measurement, compound 4: 52.1 percentage points above; measured number below the stated range.
By their numbers in this assay, from the lowest: compound 4; then compounds 2 and 3 (each within the scatter of the next); then compound 1.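

In this assay the swap to 1H-pyrazol-4-yl on the aromatic carbon meta to a large group is far from neutral, and the read-out falls sharply (a number 42.6 percentage points lower from compound 2 to compound 4 (beyond the scatter)). Here the pyrazole without the methyl is the lower partner, opposite to the earlier pair (a number 15.1 percentage points lower from compound 1 to compound 3 (beyond the scatter)), so the direction of such a change does not carry over between these places.

As far as these compounds go, the swap alters both the methyl and the ring attachment, so which of them accounts for the fall stays open, as does how a phenyl or pyridin-3-yl ring would read at this place. No measured data at hand offer an explanation for the fall.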